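Compound 4: Swapping the Group on the Carbonyl Carbon

A few compounds are considered here, and "the series" means these few. Any claim that something is new, unique, unknown or untested is made for them only; others in the source may bear on it.

Measured in an ADME assay on FHC cells (Homo sapiens) for cytotoxicity, read by resazurin assay, with a stated time of 48 h; a higher number here means that more compound is tolerated, a lower number that less compound is tolerated:
- compound 1 `COc1ccc(S(=O)(=O)Nc2ccc(-c3nc4cc(NS(=O)(=O)c5ccc(OC)cc5)ccc4o3)cc2)cc1`: 57000 nM
- compound 2 `COc1ccc(S(=O)(=O)Nc2ccc3oc(-c4ccc(NC(=O)c5cccc(C)c5[N+](=O)[O-])cc4)nc3c2)cc1`: > 100000 nM (a limit)
- compound 3 `O=S(=O)(Nc1ccc(-c2nc3cc(NS(=O)(=O)c4ccc(Br)cc4)ccc3o2)cc1)c1ccc(Br)cc1`: 18000 nM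

Compound 2 gives no number, only a limit. It stands at the limit of > 100000 nM in this assay, at which 1 of the 3 values shown sits.

Compound 4 `COc1ccc(S(=O)(=O)Nc2ccc3oc(-c4ccc(NC(=O)c5ccc(Cl)s5)cc4)nc3c2)cc1` has not yet been measured in this assay. It differs from compound 2 as follows: 5-chlorothiophen-2-yl in place of 3-methyl-2-nitrophenyl on a carbonyl carbon. For the measured compounds named here, only one measured step touches this part of the molecule, an at least 1.7-fold higher number from compound 1 to compound 2 (0.24 log units; that floor lies within the scatter). That step brought in the (3-methyl-2-nitrophenyl)carbonyl that compound 4 now gives up for (5-chlorothiophen-2-yl)carbonyl. Going by the values given here, no measured step changes the group on this carbonyl carbon, so the expectation remains loose. The numbers that do exist are compound 1 at 57000 nM and compound 3 at 18000 nM, and they suggest a modest fall. They do not make it certain that compound 4 stays at the limit. The expected change in this assay is an at least 1.4-fold lower number from compound 2 to compound 4 (0.15 log units; that floor lies within the scatter). For compound 4 the estimated value is 70000 nM, with an expected range of 25000 nM to 100000 nM.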

Compound 4, half-maximal cytotoxic concentration: > 100000 nM
Compound 4: only a limit was reported; the forecaster's own chance of this, stated with the estimate: 35%; middle value at least 1.4-fold (0.15 log units) away from the limit.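

In this assay compound 4 gives only a limit, not a number, so 5-chlorothiophen-2-yl joins 3-methyl-2-nitrophenyl as a second group on this carbonyl carbon that yields no readable value. Putting (5-chlorothiophen-2-yl)carbonyl in place of (4-methoxyphenyl)sulfonyl on a nitrogen on an aromatic ring gives an at least 1.7-fold higher number from compound 1 to compound 4 (0.24 log units; that floor lies within the scatter) and thus the same floor as an at least 1.7-fold higher number from compound 1 to compound 2 (0.24 log units; that floor lies within the scatter) with a different carbonyl group. The step between the two carbonyl groups cannot be read, since compound 2 and compound 4 both end at a limit: the limit of > 100000 nM in this assay, at which 2 of the 4 values shown sit.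

As far as these compounds go, how far compound 2 and compound 4 actually lie past that limit stays open. Also open, from the compounds shown here alone, is whether an amine or a longer alkyl chain on this carbonyl carbon would give a readable number.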